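A methoxy in place of a methyl

A few compounds are considered here, and "the series" means these few. Any claim that something is new, unique, unknown or untested is made for them only; others in the source may bear on it.

Compound 1 `CCC1=C(O)c2c(oc(-c3ccc(O)cc3)cc2=O)C(CC)(CC)C1=O` gives 20.6 uM
Compound 2 `CCC1=C(O)c2c(oc(-c3ccc(C)cc3C)cc2=O)C(CC)(CC)C1=O` gives 8.52 uM

Compound 2 sits at 8.52 uM in a functional assay on KBVIN cells (Homo sapiens) for antiproliferative activity, read by sulforhodamine B assay, with a stated time of 3 days (on this read-out higher numbers stand for an effect only at larger amounts of compound and lower numbers for an effect already at smaller amounts), and holds the lower of the two numbers. Compound 3 `CCC1=C(O)c2c(oc(-c3ccc(OC)cc3C)cc2=O)C(CC)(CC)C1=O` has methoxy in place of methyl on an aromatic carbon, para to a large group (methoxy in place of methyl on an aromatic carbon). Going by the values given here, only one measured step bears on this (a 2.4-fold lower number from compound 1 to compound 2 (0.38 log units; beyond the scatter)), and it was modest, with 2,4-dimethylphenyl in place of 4-hydroxyphenyl, a wider swap than this one. A step within the scatter is therefore expected (a 1.1-fold higher number from compound 2 to compound 3 (0.02 log units; within the scatter)), with no clear direction in this assay either way. For compound 3 the estimated value is 9 uM with an expected range from 4 uM to 20 uM across repeated measurements.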

Compound 3, concentration for half-maximal effect: 2.62 uM
Compound 3: the middle estimate sits 3.4-fold (0.54 log units) above what was measured; measured number below the stated range.
By their numbers in this assay, from the lowest: compound 3; then compound 2; then compound 1.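

Replacing the methyl para to a large group with a methoxy gives a 3.3-fold lower number from compound 2 to compound 3 (0.51 log units; beyond the scatter) and so moves the result beyond the usual scatter, where a lower number means an effect at smaller amounts of compound. Measured against the 4-hydroxyphenyl group, the 4-methoxy-2-methylphenyl group gives a 7.9-fold lower number from compound 1 to compound 3 (0.90 log units; beyond the scatter) and shows that this group outperforms both earlier ones. Nothing available explains this gain.

As far as these compounds go, whether an ethoxy or an amine at the same carbon would lower the number further remains open. So does the part played by the methyl that stays on the ring.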